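Butyl in Place of Trifluoromethyl: Compound 1 to Compound 3

The source may hold more compounds than are shown below. What is called first, only, known or untested is meant among the compounds shown, and "the series" means these compounds.

Compound 1: `CC(C)c1ccc(OC(C)(Cc2cccc(C(F)(F)F)c2)C(=O)O)cc1` — 5 mg/kg
Compound 2: `CCCc1ccc(CC(C)(Oc2ccc(C(C)C)cc2)C(=O)O)cc1` — 0.5 mg/kg

In a functional assay on the whole organism for inhibition, with Rattus norvegicus as the target (a lower number here means that less compound is needed, a higher number that more compound is needed for the effect), compound 1 gives 5 mg/kg, the highest of the two numbers measured, while compound 2 gives 0.5 mg/kg, a gap beyond the scatter. Compound 3, `CCCCc1cccc(CC(C)(Oc2ccc(C(C)C)cc2)C(=O)O)c1`, has not yet been measured. It differs from compound 1 in one place: butyl in place of trifluoromethyl on an aromatic carbon. Since compound 2 already shows that a plain alkyl chain on the shared core can go with the lower number 0.5 mg/kg, a step downward beyond the scatter is expected from compound 1 to compound 3, of about a 4.2-fold lower number from compound 1 to compound 3 (0.62 log units; beyond the scatter). Compound 3 is therefore estimated at 1.2 mg/kg, expected between 0.3 mg/kg and 4 mg/kg.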

Compound 3, dose for half-maximal effect: 1 mg/kg
Estimate against measurement, compound 3: 1.2-fold (0.08 log units) above; the measured number falls inside the stated range.
By their numbers in this assay, from the lowest: compounds 2 and 3 (each within the scatter of the next); then compound 1.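

Within the data shown here, the step of a 5.0-fold lower number from compound 1 to compound 3 (0.70 log units; beyond the scatter) in this assay is the first direct reading at this position, on an aromatic carbon meta to a large group, since compound 2 differs from compound 1 in more than one place. It shows that butyl in place of trifluoromethyl, with the same count of heavy atoms, moves the number beyond the scatter. Nothing measured bears on the reason for this step. The compounds shown leave open how a longer chain such as hexyl, a shorter one such as ethyl, or an amine would read at this position.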